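From 4-chlorophenyl to 3-chlorophenyl on a shared core

This account rests on a few compounds, and the source may have more. Where it says the series, first, only, none or still open, it means among the compounds named here.

In a functional assay on T98G cells (Homo sapiens) for inhibition, read by MTT assay, with a stated time of 72 h (on this read-out higher numbers stand for weaker inhibition and lower numbers for stronger inhibition), compound 3 (`CC1(C)CC(NC(=O)Nc2ccc(Cl)cc2)c2cc(F)ccc2O1`) gives 30000 nM as its reading. Compound 2 (`CC1(C)CC(NC(=O)Nc2ccccc2Cl)c2cc(F)ccc2O1`) gives 27000 nM as its reading, which lies within the scatter of compound 3. Compound 1 (`CC1(C)CC(NC(=O)Nc2cccc(Cl)c2)c2cc(Br)ccc2O1`) gives 67000 nM as its reading, higher than that of compound 3 by more than the scatter.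

Compound 4 (`CC1(C)CC(NC(=O)Nc2cccc(Cl)c2)c2cc(F)ccc2O1`) has not yet been measured. It departs from compound 3 through 3-chlorophenyl in place of 4-chlorophenyl on an amide-type nitrogen with 3-chlorophenyl in place of 4-chlorophenyl on an amide-type nitrogen.

Going by the values given here, one measured step bears on this change. The step of a 1.1-fold higher number from compound 2 to compound 3 (0.05 log units; within the scatter) puts 4-chlorophenyl in place of 2-chlorophenyl on the same kind of nitrogen and stays within the scatter. Among the compounds with values here, compound 1 also carries 3-chlorophenyl, but it differs from compound 3 in more than one place and so offers no clean step. The data therefore hold no direct measurement of the 3-chlorophenyl group on the core of compound 3.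

On the strength of that single small step, no change beyond the scatter is expected, and the estimated step is a 1.1-fold higher number from compound 3 to compound 4 (0.03 log units; within the scatter) in this assay terms. For compound 4 the estimated value is 32000 nM with an expected range from 16000 nM to 65000 nM in this assay once it is measured.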

Compound 4, half-maximal inhibitory concentration: 45000 nM
Compound 4: the middle estimate sits 1.4-fold (0.15 log units) below what was measured, within the range that was stated.
By their numbers in this assay, from the lowest: compounds 2, 3, 4 and 1 (each within the scatter of the next, the first and the last beyond it).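

In this assay, the step of a 1.5-fold higher number from compound 3 to compound 4 (0.18 log units; within the scatter) and the step of a 1.7-fold higher number from compound 2 to compound 4 (0.22 log units; within the scatter) complete the set of 2-chlorophenyl, 3-chlorophenyl and 4-chlorophenyl on the amide-type nitrogen of the shared core, and no two of the three can be told apart on this read-out. Going by these compounds alone, compound 4 also supplies the first one-place comparison at the halogen on the aromatic carbon: the step of a 1.5-fold lower number from compound 1 to compound 4 (0.17 log units; within the scatter) puts fluoro in place of bromo with 3-chlorophenyl held fixed, and this change also cannot be distinguished from the usual scatter. No measurement accompanies these readings that could account for them.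

The compounds shown leave open whether any substituent on the phenyl group other than chloro, such as methoxy, nitrile or a carboxylic acid, would produce a step beyond the scatter on this core. They also leave open whether fluoro and bromo would remain indistinguishable with 2-chlorophenyl or 4-chlorophenyl on the nitrogen, and whether an amine or a longer chain in place of either halogen would change the reading.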